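The compounds below may be only part of what the source reports. "The series", "measured", "known", "first", "only" and "open" are said of these compounds alone.

Three compounds have so far been measured in a functional assay on HepG2 cells (Homo sapiens) for antiproliferative activity, read by MTT assay, with a stated time of 48 h; on this read-out lower numbers stand for stronger inhibition and higher numbers for weaker inhibition:

Compound 1 `COc1ccc(/C=C/c2cc(OC)cc(OC)c2/C=C/C(=O)c2ccc(Cl)c(Cl)c2)cc1`: 10.8 ug/mL
Compound 2 `COc1ccc(/C=C/c2cc(OC)cc(OC)c2/C=C/C(=O)c2cccc(Br)c2)cc1`: 13 ug/mL
Compound 3 `COc1ccc(/C=C/c2cc(OC)cc(OC)c2/C=C/C(=O)c2cccc(Cl)c2)cc1`: 9.5 ug/mL

Compound 3 carries the lowest of the three numbers, but a 1.1-fold lower number from compound 1 to compound 3 (0.06 log units; within the scatter) and a 1.4-fold lower number from compound 2 to compound 3 (0.14 log units; within the scatter) are both within the scatter, so the three are not separated. Compound 4 `COc1ccc(/C=C/c2cc(OC)cc(OC)c2/C=C/C(=O)c2ccc(OC)cc2)cc1` is not yet measured. Its change is 4-methoxyphenyl in place of 3-chlorophenyl on a carbonyl carbon. Every measured step alters the same aryl group on the carbonyl carbon, and all stayed within the scatter: a 1.2-fold higher number from compound 1 to compound 2 (0.08 log units; within the scatter), a 1.1-fold lower number from compound 1 to compound 3 (0.06 log units; within the scatter) and a 1.4-fold lower number from compound 2 to compound 3 (0.14 log units; within the scatter). None of them exchanges a halogen for a methoxy group, so the precedent is indirect. The expected step is a 1.3-fold higher number from compound 3 to compound 4 (0.10 log units; within the scatter), not beyond the scatter. Compound 4 is estimated at 12 ug/mL, between 5 ug/mL and 30 ug/mL.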

Compound 4, half-maximal inhibitory concentration: 4.9 ug/mL
Compound 4: middle estimate off by 2.4-fold (0.39 log units), on the high side; the measured number lies below the stated range.
By their numbers in this assay, from the lowest: compounds 4, 3, 1 and 2 (each within the scatter of the next, the first and the last beyond it).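

For the compounds shown here, on the aryl group at the carbonyl carbon, 4-methoxyphenyl is the first group to separate from any other in this assay, with a 2.7-fold lower number from compound 2 to compound 4 (0.42 log units; beyond the scatter) and a 2.2-fold lower number from compound 1 to compound 4 (0.34 log units; beyond the scatter) both modest but beyond the scatter. Compound 3 goes against a clean split, since a 1.9-fold lower number from compound 3 to compound 4 (0.29 log units; within the scatter) remains within the scatter. Nothing available accounts for this difference.

On these data alone, the change replaces both the substituent and its place on the ring, so the contribution of each stays open. As far as these compounds go, how an amine or a carboxylic acid would behave on this aryl group also remains open.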